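The source may report more compounds than this note shows. Statements on the series, on what has been measured and on what is new or still open speak of the compounds shown alone.

Measured compounds:
compound 1 `Cc1c(C)c(C)c(Cn2ccnc2)c(C)c1C` — 12%
compound 2 `c1ccc(-c2cccc(Cn3ccnc3)c2)cc1` — 38%
compound 3 `c1ccc(C(CCn2cnc3ccccc32)(c2ccccc2)c2ccccc2)cc1` — "not active" (no number reported)

In an assay for inhibition of Aromatase (Homo sapiens), using microsomes, tested at 500 nM (a lower number here means less inhibition, a higher number more inhibition at the concentration tested (going by the name of the read-out)), compound 2 gives 38%, the higher of the two numbers recorded. Compound 1 gives 12% in this assay, a gap beyond the usual scatter. For the measured compounds named here, compound 3 is reported in this assay as "not active" (no number reported), with no number attached, so it gives no scale for any step.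

Compound 4 `c1ccc(-c2cc(Cn3ccnc3)cc(-c3ccccc3)c2)cc1` is the next compound in the series and has not yet been measured in this assay. It differs from compound 2 in one place: phenyl in place of hydrogen on an aromatic carbon. Going by the values given here, no step between two measured compounds matches this change, so its direction cannot be read from the set. Compound 2 already carries one phenyl group and stands highest; compound 3, which carries several, has no number. On this basis a step of moderate size in either direction, or none beyond the scatter, is the expectation.

For compound 4 the estimate is 40%, within 15% to 65%, which means an expected step of a number 2 percentage points higher from compound 2 to compound 4 (within the scatter).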

Compound 4, a percentage reported as inhibition, at one concentration (the size of the read-out at that concentration, not a potency): 12%
Estimate against measurement, compound 4: 28 percentage points above, and the stated range ends above it.
By their numbers in this assay, from the lowest: compounds 1 and 4 (each within the scatter of the next); then compound 2.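

For the compounds shown here, the step of a number 26 percentage points lower from compound 2 to compound 4 (beyond the scatter) in this assay is the first measured change in one place, and it is beyond the scatter. At this aromatic carbon, meta to the (1H-imidazol-1-yl)methyl group and meta to the phenyl group, phenyl in place of hydrogen therefore lowers inhibition at the concentration tested, so a second phenyl does not extend the higher value of compound 2. No measurement shown offers an explanation for this drop.

On these data alone, it remains open whether a smaller group on the same carbon, such as methyl, fluorine or methoxy, would give a higher, lower or level number, or whether an amine or a carboxylic acid there would behave differently. As far as these compounds go, it is also open whether the same phenyl would lower inhibition on a core without the phenyl group already present in compound 2.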